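This account rests on a few compounds, and the source may have more. Where it says the series, first, only, none or still open, it means among the compounds named here.

Working notes on the series. Three compounds have numbers in a functional assay on DU-145 cells (Homo sapiens) for inhibition, read by trypan blue exclusion, with a stated time of 96 h; on this read-out higher numbers stand for weaker inhibition of growth and lower numbers for stronger inhibition of growth. Compound 1 `O=C(O)c1ccc(C(=O)/C(=C\c2ccc(Br)c([N+](=O)[O-])c2)SCc2ccccc2Cl)cc1` gives 1000 nM. Compound 2 `O=C(/C(=C\c1csc([N+](=O)[O-])c1)S(=O)(=O)c1ccc(Br)cc1)c1ccc(Br)cc1` gives 1000 nM, level with compound 1 at the digits shown, the two together the lowest of the three. Among the compounds with values here, compound 3 `COc1ccc(/C=C(\C(=O)c2ccc(Cl)cc2)S(=O)(=O)c2ccc(Br)cc2)cc1` gives 10000 nM, a higher number than compound 2 and the only one of the three that lies beyond the scatter from it; compound 3 is the only compound so far with a carbon-only six-membered ring on the double-bonded chain carbon.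

Compound 4 `O=C(/C(=C\c1ccc(F)cc1Cl)S(=O)(=O)c1ccc(Br)cc1)c1ccc(Br)cc1` is not yet measured. It differs from compound 2 in one place: 2-chloro-4-fluorophenyl in place of 5-nitrothiophen-3-yl on a double-bonded chain carbon bound to a double-bonded chain carbon. Within the data shown here, no pair of measured compounds differs in exactly this way, so the size of the step is open. Still, compound 3 shows that a carbon-only ring in this place can go with a weaker number, 10000 nM, and so a step toward weaker inhibition is expected for compound 4, though smaller than the gap from compound 2 to compound 3. The expected step is a 3.0-fold higher number from compound 2 to compound 4 (0.48 log units; beyond the scatter). Compound 4 is therefore estimated at 3000 nM, with a range from 1000 nM to 10000 nM.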

Compound 4, concentration for 50% growth inhibition: 50000 nM
Compound 4: middle estimate off by 17-fold (1.22 log units), on the low side; measured number outside the range, above it.
By their numbers in this assay, from the lowest: compounds 1 and 2 (each within the scatter of the next); then compound 3; then compound 4.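

In this assay, within the data shown here, 2-chloro-4-fluorophenyl in place of 5-nitrothiophen-3-yl on a double-bonded chain carbon bound to a double-bonded chain carbon gives a 50-fold higher number from compound 2 to compound 4 (1.70 log units; beyond the scatter) and is the first single-place change that can be read, so the group at this position matters for the number. The two groups have the same count of heavy atoms, while the leaving group carries hydrogen-bond acceptors and the entering group carries none. No measurement at hand gives a cause for this step.

This one change alters the ring, the nitro group and the halogens together, so their separate contributions cannot be read. On these data alone, how an unsubstituted thiophen-3-yl or a thiophene ring bearing an amine would read at this place remains open.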